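A closer look at swapping one amide substituent

The compounds below may be only part of what the source reports. "The series", "measured", "known", "first", "only" and "open" are said of these compounds alone.

Compound 2 `CCCN(C(=O)CN(C)C(=O)c1ccc(S(C)(=O)=O)c([N+](=O)[O-])c1)c1ccccc1` was tested in an assay on isolated protein for inhibition of thyroid hormone receptor alpha (Homo sapiens), read by fluorescence polarization; on this read-out lower numbers stand for stronger inhibition and higher numbers for weaker inhibition. In this assay compound 2 gives only a limit, > 60000 nM, so no exact number is known for it; it sits at the limit of > 60000 nM in this assay, at which 1 of the 2 values shown sits. Compound 1 `CS(=O)(=O)c1ccc(C(=O)NCC(=O)N(Cc2ccccc2)Cc2ccccc2)cc1[N+](=O)[O-]`, which shares the same core, gives 1700 nM in this assay. Compound 3 `CN(Cc1cccc(F)c1)C(=O)CN(C)C(=O)c1ccc(S(C)(=O)=O)c([N+](=O)[O-])c1` has not yet been measured and carries (3-fluorobenzyl)(methyl)amino in place of phenyl(propyl)amino on a carbonyl carbon. Going by the values given here, no measured step covers this change, so the expectation leans on compound 1, which also bears a benzyl on the amide and gives 1700 nM. Compound 3 is therefore estimated at 15000 nM, expected to fall between 3000 nM and 60000 nM. The expected step from compound 2 to compound 3 is an at least 4.0-fold lower number from compound 2 to compound 3 (0.60 log units; beyond the scatter).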

Compound 3, half-maximal inhibitory concentration: > 60000 nM
Compound 3: only a limit was reported; the forecaster's own chance of this, stated with the estimate: 35%; middle value at least 4.0-fold (0.60 log units) away from the limit.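

No step can be read from compound 2 to compound 3, since each gives only a limit, not a number: the limit of > 60000 nM in this assay, at which 2 of the 3 values shown sit.

The compounds shown leave open whether (3-fluorobenzyl)(methyl)amino in place of phenyl(propyl)amino changes inhibition at all.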